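The compounds below may be only part of what the source reports. "The series", "measured", "known", "first", "only" and "open" are said of these compounds alone.

The measured compounds:
Compound 1, `C/C(=C\c1cc(-c2ccc(C)nc2)co1)C(N)=O`, in a functional assay on HO8910 cells (Homo sapiens) for cytotoxicity, read by CCK-8 assay, with a stated time of 24 h (on this read-out lower numbers stand for stronger inhibition and higher numbers for weaker inhibition), gives a value that is only a limit, > 50000 nM.
Compound 2, `C/C(=C\c1cc(-c2ccc(F)nc2)co1)C(N)=O`, in this assay gives 30000 nM.
Compound 3, `C/C(=C\c1ccc(-c2ccc(C)cc2)o1)C(N)=O`, in this assay gives 1660 nM.

From compound 1 to compound 2 the change is fluoro in place of methyl on an aromatic carbon, and the step is an at least 1.6-fold lower number from compound 1 to compound 2 (0.22 log units; that floor lies within the scatter); its size is only a floor, since the starting value sits at the limit of > 50000 nM in this assay, at which 1 of the 3 values shown sits. Compound 3 has a different core from compound 1; how the two cores differ is not broken down here. Among the measured compounds, the number for compound 3 stands well apart from that of compound 2.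

Compound 4, `C/C(=C\c1ccc(-c2ccc(F)cc2)o1)C(N)=O`, is not yet measured. Its change from compound 3 is fluoro in place of methyl on an aromatic carbon. This is the same kind of change as from compound 1 to compound 2, but the place differs: there the group sits on a six-membered aromatic ring with 1 nitrogen, next to the ring nitrogen, whereas here it sits on a six-membered aromatic ring of carbon only. Resting on that single earlier step, a small step is expected, a 1.4-fold lower number from compound 3 to compound 4 (0.14 log units; within the scatter). Compound 4 is thus estimated at 1200 nM, with a likely range from 400 nM to 4000 nM.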

Compound 4, half-maximal inhibitory concentration: 990 nM
Estimate against measurement, compound 4: 1.2-fold (0.08 log units) above; the range from low to high includes it.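

On the ring of carbon only, fluoro in place of methyl gives a 1.7-fold lower number from compound 3 to compound 4 (0.22 log units; within the scatter) in this assay, so on this core the swap produces no change that can be told apart from ordinary variation between repeated measurements. Setting this step beside the one on the other core gives only a partial comparison: the same change on two cores in this assay, an at least 1.6-fold lower number (0.22 log units; that floor lies within the scatter) from compound 1 to compound 2 and a 1.7-fold lower number (0.22 log units; within the scatter) from compound 3 to compound 4; the limit leaves it open whether they differ. Compound 1 gives > 50000 nM, which is a limit and not a number, so the data show neither that the change carries over from one core to the other with the same size nor that it does not.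

The compounds shown leave open how other groups would behave at this place on the ring of carbon only, for example an amine, a carboxylic acid or a longer chain in place of methyl or fluoro. They also leave open how fluoro and methyl would compare at other places on that ring.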